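A benzyl replaces the aminopropyl carbonyl on compound 3

The compounds below may be only part of what the source reports. "The series", "measured", "known", "first", "only" and "open" are said of these compounds alone.

In an ADME assay on L929 cells (Mus musculus) for cytotoxicity, read by resazurin assay, with a stated time of 72 h (on this read-out lower numbers stand for stronger inhibition and higher numbers for weaker inhibition), compound 3 `NCCCC(=O)c1ccn(-c2ccc3c(c2)B(O)OC3)c1` gives only a limit, > 10 ug/mL. Compound 1 `OB1OCc2ccc(-n3cccc3)cc21` gives a limit as well, > 10 ug/mL. Compound 2 `CC(=O)c1ccn(-c2ccc3c(c2)B(O)OC3)c1` likewise gives a limit, > 10 ug/mL. All three values sit at the limit of > 10 ug/mL in this assay, at which 3 of the 3 values shown sit. The step that the two limits leave unreadable from compound 1 to compound 2 therefore has no readable size. Compound 4 `OB1OCc2ccc(-n3ccc(Cc4ccccc4)c3)cc21` differs from compound 3 by benzyl in place of (3-aminopropyl)carbonyl on an aromatic carbon. The steps that touch the leaving group, a step that the two limits leave unreadable from compound 1 to compound 3 and a step that the two limits leave unreadable from compound 2 to compound 3, are equally unreadable, so neither a size nor a direction can be drawn from them. Compound 4 is thus expected to stay near the limit, with the step that the limit leaves unreadable from compound 3 to compound 4 estimated as small. For compound 4 the estimate in this assay is 12 ug/mL, with a range from 4 ug/mL to 40 ug/mL.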

Compound 4, half-maximal inhibitory concentration: > 10 ug/mL
Compound 4: a limit, no number; the forecaster's own chance of this, stated with the estimate: 60%; the middle value lies beyond the limit too.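

In this assay compound 4 gives only a limit, > 10 ug/mL, so its steps from compound 1, compound 2 and compound 3 cannot be read. The compounds shown leave open whether any substitution changes cytotoxicity, because all share one limit: the limit of > 10 ug/mL in this assay, at which 4 of the 4 values shown sit.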